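A few compounds are considered here, and "the series" means these few. Any claim that something is new, unique, unknown or untested is made for them only; others in the source may bear on it.

The series shares one core, carried by compound 1 `O=[N+]([O-])c1cc(CSc2nnc(-c3ccccc3)n2C2CCCCC2)cc([N+](=O)[O-])c1`, compound 2 `COc1ccc(Cn2c(SCc3cc([N+](=O)[O-])cc([N+](=O)[O-])c3)nnc2-c2ccccc2)cc1` and compound 3 `O=[N+]([O-])c1cc(CSc2nnc(-c3ccccc3)n2Cc2ccccc2)cc([N+](=O)[O-])c1`. In an ADME assay on HepG2 cells (Homo sapiens) for cytotoxicity, with a stated time of 48 h (on this read-out lower numbers stand for stronger inhibition and higher numbers for weaker inhibition), compound 1 gives only a limit of > 30000 nM. In this assay compound 2 likewise gives only a limit of > 30000 nM. In this assay compound 3 also gives only a limit of > 30000 nM. Compound 3 therefore stands at the same limit as the other two, and the three changes among the measured compounds, a step that the two limits leave unreadable from compound 1 to compound 2, a step that the two limits leave unreadable from compound 1 to compound 3 and a step that the two limits leave unreadable from compound 2 to compound 3, yield no readable size. For the measured compounds named here, the single piece of evidence is the limit of > 30000 nM in this assay, at which 3 of the 3 values shown sit. Compound 4 `O=[N+]([O-])c1cc(CSc2nnc(-c3ccc(Br)cc3)n2Cc2ccccc2)cc([N+](=O)[O-])c1` differs from compound 3 by bromo in place of hydrogen on an aromatic carbon, a change on the phenyl group rather than on the aromatic nitrogen that varies among the measured compounds. Going by the values given here, no measured step bears directly on this change, and all three are unreadable, so neither size nor direction can be drawn from them. Because every value shown sits at the limit of > 30000 nM in this assay, at which 3 of the 3 values shown sit, compound 4 is expected to rest at or near the same limit, with the step that the limit leaves unreadable from compound 3 to compound 4 estimated as essentially none. The estimate for compound 4 in this assay is 40000 nM, within 15000 nM to 150000 nM.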

Compound 4, half-maximal inhibitory concentration: > 30000 nM
Compound 4 ended at the assay's limit; the forecaster's own chance of this, stated with the estimate: 75%; the middle value lies beyond the limit too.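

In this assay, compound 3 and compound 4 both rest at the assay's limit, so no step can be read between them. The compounds shown leave open how far any of the four lies beyond that limit, and whether any change to the shared core would give a readable value.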